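Chalcone Ketone Aryl Variation and Cytotoxicity in ZR-75-1 Cells

The compounds below may be only part of what the source reports. "The series", "measured", "known", "first", "only" and "open" are said of these compounds alone.

The measured compounds and their values:
Compound 1, `O=C(/C=C/c1cccc(OCc2ccccc2)c1)c1cccc(Br)c1`: 8300 nM
Compound 2, `O=C(/C=C/c1cccc(OCc2ccccc2)c1)c1ccc(Cl)cc1Cl`: 9400 nM

In a functional assay on ZR-75-1 cells (Homo sapiens) for cytotoxicity, read by MTT assay, with a stated time of 68 h (on this read-out higher numbers stand for weaker inhibition and lower numbers for stronger inhibition), compound 1 gives 8300 nM, and compound 2 gives 9400 nM. Among the measured compounds shown here, the one step that has been measured, a 1.1-fold higher number from compound 1 to compound 2 (0.05 log units; within the scatter), changes only the aryl group on the carbonyl carbon, and it leaves the number essentially where it was. Compound 2 therefore stands at the higher of the two numbers, but its gap to compound 1 is within the scatter, so the two compounds cannot be told apart on this assay.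

Compound 3, `O=C(/C=C/c1cccc(OCc2ccccc2)c1)c1ccc([N+](=O)[O-])cc1`, has not yet been measured. It differs from compound 2 in the same place: 4-nitrophenyl in place of 2,4-dichlorophenyl on a carbonyl carbon. For the measured compounds named here, the only step that bears on this change is the one from compound 1 to compound 2, which was within the scatter, and no step involving a 4-nitrophenyl group has been measured. On that basis a step of about a 1.0-fold lower number from compound 2 to compound 3 (0.02 log units; within the scatter) is expected, that is, no change beyond the scatter in either direction. Compound 3 is therefore estimated at 9000 nM in this assay, with a range from 3000 nM to 27000 nM.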

Compound 3, half-maximal inhibitory concentration: 37700 nM
Beside the measured number, compound 3's estimate is 4.2-fold (0.62 log units) below it; measured number outside the range, above it.
By their numbers in this assay, from the lowest: compounds 1 and 2 (each within the scatter of the next); then compound 3.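

The position on the carbonyl carbon proves not to be indifferent to the aryl group it carries: in this assay, the change to 4-nitrophenyl gives a 4.0-fold higher number from compound 2 to compound 3 (0.60 log units; beyond the scatter), and the comparison with the 3-bromophenyl compound gives a 4.5-fold higher number from compound 1 to compound 3 (0.66 log units; beyond the scatter). The earlier step, a 1.1-fold higher number from compound 1 to compound 2 (0.05 log units; within the scatter), had shown only that 3-bromophenyl and 2,4-dichlorophenyl could not be told apart, so these three compounds now fall into two levels, with the two halogen-bearing aryl groups together and 4-nitrophenyl, which carries nitrogen and oxygen and no halogen, at the weaker end. No measured evidence is available to explain why this aryl change shifts the number.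

The compounds shown leave open whether the shift belongs to the nitro group itself or simply to the loss of halogen, since 4-nitrophenyl differs from both other aryl groups in its substituent and in the substituent's place on the ring. An amine, a methoxy group or a nitrile on the same aryl ring would be needed to separate these readings and to show whether other groups follow the nitro group or stay with the halogens.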